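This account rests on a few compounds, and the source may have more. Where it says the series, first, only, none or still open, it means among the compounds named here.

The measured compounds in a functional assay on CCRF-CEM cells (Homo sapiens), read by MTT assay, with a stated time of 72 h; a higher number here means a weaker inhibitor, a lower number a stronger inhibitor:
compound 1, `COc1ncnc2c1c(-c1cccs1)cn2[C@@H]1O[C@H](CO)[C@@H](O)[C@H]1O`, gives 90 nM.
compound 2, `COc1nc(N)nc2c1c(-c1cccs1)cn2[C@@H]1O[C@H](CO)[C@@H](O)[C@H]1O`, gives only a limit, > 20000 nM.
compound 3, `CN(C)c1ncnc2c1c(-c1cccs1)cn2[C@@H]1O[C@H](CO)[C@@H](O)[C@H]1O`, gives only a limit, > 20000 nM.

For the measured compounds named here, compound 1 therefore holds the only actual number in this assay; the other two results are limits. The two measured steps both lead away from it and both are large: an at least 220-fold higher number from compound 1 to compound 2 (2.34 log units; beyond the scatter), and an at least 220-fold higher number from compound 1 to compound 3 (2.34 log units; beyond the scatter). On these data alone, each of these steps ends at the limit of > 20000 nM in this assay, at which 2 of the 3 values shown sit, so their true size is unknown beyond that floor. Both touch the six-membered ring of the shared core, one by an amino group, one by a dimethylamino group replacing methoxy.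

Compound 4, `COc1ncnc2c1c(-c1ccco1)cn2[C@@H]1O[C@H](CO)[C@@H](O)[C@H]1O`, changes something else: furan-2-yl in place of thiophen-2-yl on an aromatic carbon. Neither measured step alters the five-membered aromatic substituent, so neither bears directly on this change, and no evidence on the size of such a swap exists among these compounds. The furan-2-yl group matches the thiophen-2-yl group in ring size and in hydrogen-bond donor and acceptor count, so only a modest step, if any, is expected in this assay, with a slight lean toward a higher number. Compound 4 is thus estimated at 160 nM, within 40 nM to 700 nM, which would mean an expected step of a 1.8-fold higher number from compound 1 to compound 4 (0.25 log units; within the scatter).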

Compound 4, half-maximal inhibitory concentration: 20 nM
The estimate for compound 4 lay 8.0-fold (0.90 log units) above the measured number, and the stated range ends above it.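

In this assay, the aromatic carbon of the five-membered aromatic ring with 1 nitrogen, which no earlier change touched, proves sensitive to the group it carries: furan-2-yl in place of thiophen-2-yl gives a 4.5-fold lower number from compound 1 to compound 4 (0.65 log units; beyond the scatter). This is the only step shown with actual numbers at both ends and the only one toward a lower number, so its size is known, whereas the earlier steps end at limits. The two groups match in heavy-atom count, ring size and counted hydrogen-bond donors and acceptors, and differ in that oxygen stands where sulfur stood, but nothing shown here explains why this swap gives a lower number.

On these data alone, whether the trend continues at this position remains open, for example with phenyl, furan-3-yl or thiophen-3-yl, or with a small chain such as methyl or ethyl. Also open, as far as these compounds go, is whether furan-2-yl would keep its lower number alongside an amino group on the shared core, or with dimethylamino in place of methoxy.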